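This account rests on a few compounds, and the source may have more. Where it says the series, first, only, none or still open, it means among the compounds named here.

Of the compounds shown here, two built on one shared core have been measured, and a third awaits its number. Within the data shown here, compound 1 `CC1=CSC(O)(c2ccc([N+](=O)[O-])cc2)c2noc(=O)n21` carries a different group on its six-membered aromatic ring from the one found in compound 2. In a functional assay on A2780 cells (Homo sapiens) for antiproliferative activity, read by MTT assay, with a stated time of 3 days (on this read-out lower numbers stand for stronger inhibition and higher numbers for weaker inhibition), compound 1 reaches only > 100000 nM, which is a limit of the assay rather than a number. Compound 2 `CC1=CSC(O)(c2cccc(C(F)(F)F)c2)c2noc(=O)n21` carries a trifluoromethyl group on that ring, and in this assay compound 2 gives 60000 nM. Among the values shown, compound 2 thus holds the only true number, while the other result sits at the limit of > 100000 nM in this assay, at which 1 of the 2 values shown sits. Among the measured compounds shown here, no step between two measured compounds is available, so there is nothing here that shows how much a single change on the ring shifts the read-out. Compound 3 `CC1=CSC(O)(c2ccccc2)c2noc(=O)n21` has not yet been measured. It differs from compound 2 in one place: hydrogen in place of trifluoromethyl on an aromatic carbon. With compound 2 already weak at 60000 nM, the change is expected to matter little. In this assay the expected step is a 1.3-fold higher number from compound 2 to compound 3 (0.12 log units; within the scatter), not beyond the usual scatter. Compound 3 is therefore estimated at about 80000 nM, most likely between 30000 nM and 200000 nM, with a fair chance that only a limit is reported.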

Compound 3, half-maximal inhibitory concentration: > 100000 nM
Compound 3: no number, only a limit; the forecaster's own chance of this, stated with the estimate: 40%; middle value at least 1.2-fold (0.09 log units) away from the limit.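

This is the first readable step at this place on the ring: in this assay hydrogen in place of trifluoromethyl gives an at least 1.6-fold higher number from compound 2 to compound 3 (0.22 log units; that floor lies within the scatter) and that figure is only a floor, so the full size of the step stays unknown and is not shown to pass the usual scatter. Among the compounds shown, only compound 2, with its trifluoromethyl group, gives a true number, while the unsubstituted ring of compound 3 and the nitro-bearing ring of compound 1 give only limits. The step between compound 1 and compound 3 cannot be read, and the limit of the assay now holds most of the set: the limit of > 100000 nM in this assay, at which 2 of the 3 values shown sit.

On these data alone, whether trifluoromethyl really adds activity over hydrogen remains open, since a floor within the scatter cannot settle it. As far as these compounds go, it is also open whether another group on the same aromatic carbon, such as an amine, a carboxylic acid or a methoxy group, would give a true number in this assay or would stay at the limit.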